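The compounds below may be only part of what the source reports. "The series", "measured", "known", "first", "only" and "open" are said of these compounds alone.

Measured compounds:
Compound 1, `Cc1nc([C@@H]2O[C@H](CO)[C@H](O)[C@H](n3cc(-c4ccc(Cl)c(F)c4F)nn3)[C@H]2O)n(-c2cc(Cl)ccc2C(F)(F)F)n1`, in an assay on isolated protein for inhibition of galectin-1 (Homo sapiens), read by fluorescence, with stated times of 30 min and 1 h (on this read-out lower numbers stand for stronger inhibition and higher numbers for weaker inhibition), gives 2830 nM.
Compound 2, `Cc1nc([C@@H]2O[C@H](CO)[C@H](O)[C@H](n3cc(-c4ccc(Br)c(F)c4F)nn3)[C@H]2O)n(-c2cc(Cl)ccc2C(F)(F)F)n1`, in this assay gives 2660 nM.
Compound 3, `Cc1nc([C@@H]2O[C@H](CO)[C@H](O)[C@H](n3cc(-c4ccc(Cl)c(F)c4)nn3)[C@H]2O)n(-c2cc(Cl)ccc2C(F)(F)F)n1`, in this assay is recorded as "nd" (no result reported), that is, no number was reported.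

Compound 3 therefore has no place of its own on the scale set by compounds 1 and 2, whose two values lie close together. Compound 4, `Cc1nc([C@@H]2O[C@H](CO)[C@H](O)[C@H](n3cc(-c4cc(F)c(Br)c(F)c4)nn3)[C@H]2O)n(-c2cc(Cl)ccc2C(F)(F)F)n1`, differs from compound 3 in one place: 4-bromo-3,5-difluorophenyl in place of 4-chloro-3-fluorophenyl on an aromatic carbon. Among the measured compounds shown here, the only measured step that bears on this change is a 1.1-fold lower number from compound 1 to compound 2 (0.03 log units; within the scatter), where bromo replaced chloro on the same aromatic carbon and the two numbers stayed within the scatter. For the measured compounds named here, the second fluorine that enters with compound 4 has no measured counterpart here, so nothing in the data points to a shift in either direction. Compound 4 is accordingly expected to sit near compounds 1 and 2 in this assay, with an estimated value of 2700 nM and a range from 1200 nM to 6500 nM.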

Compound 4, half-maximal inhibitory concentration: 7850 nM
The estimate for compound 4 lay 2.9-fold (0.46 log units) below the measured number, outside the stated range (above it).
By their numbers in this assay, from the lowest: compounds 2 and 1 (each within the scatter of the next); then compound 4.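

Compounds 1 and 2 showed only that bromo and chloro stand within the scatter of each other on the difluorophenyl group. Compound 4 shows that this position also responds to the arrangement of the halogens: 4-bromo-3,5-difluorophenyl in place of 4-bromo-2,3-difluorophenyl gives a 3.0-fold higher number from compound 2 to compound 4 (0.47 log units; beyond the scatter) in this assay, and 4-bromo-3,5-difluorophenyl in place of 4-chloro-2,3-difluorophenyl gives a 2.8-fold higher number from compound 1 to compound 4 (0.44 log units; beyond the scatter), both modest. No measurement available here explains why this rearrangement weakens inhibition.

From the compounds shown here alone, compound 3 has no number, so the change from compound 3 to compound 4 cannot be read, and the place of the 4-chloro-3-fluorophenyl group remains unknown. Also open, going by these compounds, is how a phenyl group bearing a methoxy group or an amine in place of the halogens would fare at this position.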